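Carbamate to ester in the shared side chain

The source may report more compounds than this note shows. Statements on the series, on what has been measured and on what is new or still open speak of the compounds shown alone.

Measured so far in a functional assay on the whole organism (arterial blood) with Rattus norvegicus as the target; a higher number here means that more compound is needed for the effect, a lower number that less compound is needed
- compound 1 `COC(=O)NC(CC(=O)N1CCC(Cn2c(C)nc3cnccc32)CC1)c1ccccc1` gives 0.035 mg/kg
- compound 2 `Cc1nc2cnccc2n1C1CCN(C(=O)CC(c2ccccc2)c2ccccc2)CC1` gives 0.41 mg/kg

Of these two, compound 1 holds the lower number and needs less compound for the effect. Compound 2 lies higher, and the gap is beyond the usual scatter.

Compound 3 `CCOC(=O)C(CC(=O)N1CCC(Cn2c(C)nc3cnccc32)CC1)c1ccccc1` has not yet been measured. It carries ethoxycarbonyl in place of (methoxycarbonyl)amino on a saturated chain carbon bound to an aromatic carbon and a saturated chain carbon.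

Going by the values given here, no measured pair isolates this change, and compound 2 differs from compound 1 in more than one place, so the expectation is loose. It starts from compound 1 (0.035 mg/kg) and takes compound 2 (0.41 mg/kg) as a rough reference. A moderate step to a higher number is expected (a 3.1-fold higher number from compound 1 to compound 3 (0.50 log units; beyond the scatter)). The estimated value for compound 3 is 0.11 mg/kg (expected range 0.03 mg/kg to 0.4 mg/kg).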

Compound 3, dose for 50% inhibition: 0.17 mg/kg
For compound 3 the middle estimate is 1.5-fold (0.19 log units) below the measured one, and the stated range covers the measured number.
By their numbers in this assay, from the lowest: compound 1; then compound 3; then compound 2.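

In this assay, ethoxycarbonyl in place of (methoxycarbonyl)amino on a saturated chain carbon bound to an aromatic carbon and a saturated chain carbon gives a 4.9-fold higher number from compound 1 to compound 3 (0.69 log units; beyond the scatter). Going by these compounds alone, this is the first step that isolates a single place, and it shows that the outcome in the whole animal depends on the group at this carbon. The exchange keeps the heavy-atom count and the hydrogen-bond acceptor count but removes the hydrogen-bond donor, and no measurement here explains the step.

The exchange alters the atom bound to the chain carbon and the ester chain together, so the step cannot be assigned to either one. A methoxycarbonyl, a carboxylic acid or a primary amine on this carbon would help separate the two.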